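The source may hold more compounds than are shown below. What is called first, only, known or untested is meant among the compounds shown, and "the series" means these compounds.

Among the measured compounds shown here, compound 2 `COc1ccc(-n2c(=O)c(C(=O)Nc3ccc(Oc4ccnc5c4ccn5C)cc3)cc3cccnc32)cc1` carries the highest number of the two compounds measured so far. In a functional assay on A549 cells (Homo sapiens) for antiproliferative activity, read by MTT assay, with a stated time of 72 h (on this read-out higher numbers stand for weaker inhibition and lower numbers for stronger inhibition), compound 2 gives 3460 nM. For the measured compounds named here, its nearest neighbour is compound 1 `Cn1ccc2c(Oc3ccc(NC(=O)c4cc5cccnc5n(-c5ccccc5)c4=O)cc3)ccnc21`, which in this assay gives 850 nM; the only step recorded between measured compounds, a 4.1-fold higher number from compound 1 to compound 2 (0.61 log units; beyond the scatter), connects these two. Compound 3 `Cn1ccc2c(Oc3ccc(NC(=O)c4cc5cccnc5n(-c5ccc(F)c(Cl)c5)c4=O)cc3)ccnc21` has not yet been measured. It differs from compound 2 by 3-chloro-4-fluorophenyl in place of 4-methoxyphenyl on an aromatic nitrogen. Going by the values given here, the one measured step bears on this change only in part: it shows what the methoxy on that ring did to the number, while no measured compound in this set carries a chlorine or a fluorine on the same ring. The expectation for compound 3 therefore rests on compound 1, whose value of 850 nM belongs to the unsubstituted phenyl, with added uncertainty for the halogens. Compound 3 is estimated at 900 nM in this assay, within a range from 300 nM to 3000 nM. This corresponds to an expected step of a 3.8-fold lower number from compound 2 to compound 3 (0.58 log units; beyond the scatter).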

Compound 3, half-maximal inhibitory concentration: 820 nM
The estimate for compound 3 lay 1.1-fold (0.04 log units) above the measured number, within the range that was stated.
By their numbers in this assay, from the lowest: compounds 3 and 1 (each within the scatter of the next); then compound 2.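

In this assay, the replacement of 4-methoxyphenyl by 3-chloro-4-fluorophenyl on the aromatic nitrogen gives a 4.2-fold lower number from compound 2 to compound 3 (0.63 log units; beyond the scatter) and so reverses, in size, the step seen with the methoxy. The replacement of phenyl by the same group gives a 1.0-fold lower number from compound 1 to compound 3 (0.02 log units; within the scatter) and so leaves compounds 1 and 3 within the scatter of each other. Among the three rings shown at this position, only the 4-methoxyphenyl of compound 2 stands apart, and a ring bearing both halogens reads the same as the plain phenyl. Nothing available accounts for this difference between the methoxy and the two halogens.

The compounds shown leave open what the chlorine and the fluorine each do alone on this ring. They also leave open how an amine or a carboxylic acid on the ring would read, or a plain methyl on the nitrogen in place of the ring.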